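Morpholinyl Replacing Diisopropylamino on the Dithiocarbamate Chromone

The source may hold more compounds than are shown below. What is called first, only, known or untested is meant among the compounds shown, and "the series" means these compounds.

Compound 1 `CCOC(=O)c1cc(=O)c2cc(CSC(=S)N(C(C)C)C(C)C)ccc2o1`: > 25000 nM in a functional assay on LM7 cells (Homo sapiens) for antiproliferative activity, read by MTT assay, with a stated time of 72 h; a higher number here means a weaker inhibitor, a lower number a stronger inhibitor. Compound 2 `O=c1c(Cl)c(CSC(=S)N2CCCCC2)oc2ccccc12`: 3300 nM. Compound 3 `CC(C)N(C(=S)SCc1oc2ccccc2c(=O)c1Cl)C(C)C`: > 40000 nM.

The value of compound 1 is a limit of this assay (the limit of > 25000 nM in this assay, at which 1 of the 3 values shown sits). The value of compound 3 is likewise a limit of this assay (the limit of > 40000 nM in this assay, at which 1 of the 3 values shown sits); compound 3 therefore stands at the weak end of the numbers shown, with no exact figure. Compound 4 `O=c1c(Cl)c(CSC(=S)N2CCOCC2)oc2ccccc12` differs from compound 3 by morpholin-4-yl in place of diisopropylamino on a thiocarbonyl carbon. For the measured compounds named here, the one measured step that bears on this change is an at least 12-fold higher number from compound 2 to compound 3 (1.08 log units; beyond the scatter), where a cyclic amine on the thiocarbonyl carbon gave the lower number. Returning to a cyclic amine, morpholin-4-yl, is therefore expected to move this assay back downward, a step of an at least 6.6-fold lower number from compound 3 to compound 4 (0.82 log units; beyond the scatter). Compound 4 is estimated at 6000 nM, within 2500 nM to 20000 nM.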

Compound 4, half-maximal inhibitory concentration: 19200 nM
The estimate for compound 4 lay 3.2-fold (0.51 log units) below the measured number; the measured number falls inside the stated range.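

In this assay, a cyclic amine on the thiocarbonyl carbon does not by itself recover the number of compound 2: morpholin-4-yl gives an at least 2.0-fold lower number from compound 3 to compound 4 (0.31 log units; beyond the scatter), yet the comparison with piperidin-1-yl gives a 5.8-fold higher number from compound 2 to compound 4 (0.76 log units; beyond the scatter). The two rings therefore do not read alike, and piperidin-1-yl gives the lower number. The first step is only a bound, since the value of compound 3 is a limit of the assay: the limit of > 40000 nM in this assay, at which 1 of the 4 values shown sits.

From the compounds shown here alone, what the ring oxygen of morpholin-4-yl contributes to this gap remains open. So does how a pyrrolidine or piperazine ring would read on the thiocarbonyl carbon.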